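Difluorobenzyl positional swap on the shared core

This account rests on a few compounds, and the source may have more. Where it says the series, first, only, none or still open, it means among the compounds named here.

Three compounds of the series carry numbers in an assay for inhibition of high affinity nerve growth factor receptor (Homo sapiens), read by HTRF, with a stated time of 30 min, in the presence of a further agent that is not named here; on this read-out higher numbers stand for weaker inhibition and lower numbers for stronger inhibition. Compound 1 `Cc1cc(Nc2nc(NCc3ccc(Cl)cc3)nc3ccccc23)n[nH]1` gives 380 nM. Compound 2 `Cc1cc(Nc2nc(NCc3ccc(C#N)cc3)nc3ccccc23)n[nH]1` gives 83 nM, and the step of a 4.6-fold lower number from compound 1 to compound 2 (0.66 log units; beyond the scatter) is the largest seen. Compound 3 `Cc1cc(Nc2nc(NCc3ccc(F)cc3F)nc3ccccc23)n[nH]1` gives 200 nM, the second highest of the three numbers; the step of a 1.9-fold lower number from compound 1 to compound 3 (0.28 log units; within the scatter), whereas the step of a 2.4-fold higher number from compound 2 to compound 3 (0.38 log units; beyond the scatter).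

Compound 4 `Cc1cc(Nc2nc(NCc3ccc(F)c(F)c3)nc3ccccc23)n[nH]1` has not been measured. Relative to compound 3 the change is 3,4-difluorophenyl in place of 2,4-difluorophenyl on a saturated chain carbon bound to a nitrogen on an aromatic ring. For the measured compounds named here, no measured step moves a fluorine from one place to another on an otherwise unchanged ring; the steps of a 1.9-fold lower number from compound 1 to compound 3 (0.28 log units; within the scatter) and a 2.4-fold higher number from compound 2 to compound 3 (0.38 log units; beyond the scatter) exchange the whole ring, and only the second lies beyond the scatter. Going by the values given here, with no direct precedent, compound 4 is expected to show a step of no change at the digits printed from compound 3 to compound 4 (within the scatter), that is, nothing beyond the scatter in this assay . Compound 4 is therefore estimated at 200 nM, with a range from 80 nM to 500 nM.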

Compound 4, half-maximal inhibitory concentration: 74 nM
Compound 4: the middle estimate sits 2.7-fold (0.43 log units) above what was measured; measured number outside the range, below it.
By their numbers in this assay, from the lowest: compounds 4 and 2 (each within the scatter of the next); then compounds 3 and 1 (each within the scatter of the next).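

In this assay, for the compounds shown here, the step of a 2.7-fold lower number from compound 3 to compound 4 (0.43 log units; beyond the scatter) is the first to keep the atoms of the group unchanged and alter only how they are joined, and it lies beyond the scatter, so at this position the arrangement of the two fluorines on the ring matters, not just their presence. The 3,4-difluorophenyl group falls within the scatter of the 4-cyanophenyl group, with a 1.1-fold lower number from compound 2 to compound 4 (0.05 log units; within the scatter), and both stand apart from the 4-chlorophenyl group, with a 5.1-fold lower number from compound 1 to compound 4 (0.71 log units; beyond the scatter) for the new compound. Nothing available explains why moving a fluorine changes the number.

Open, going by these compounds, is whether an amine or a carboxylic acid on the phenyl ring would keep the number of compound 4. Also open, on these data alone, is whether a longer chain at this saturated chain carbon would preserve the difference between compound 3 and compound 4.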